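Amide-end variation on the shared core

A few compounds are considered here, and "the series" means these few. Any claim that something is new, unique, unknown or untested is made for them only; others in the source may bear on it.

Measured compounds:
- compound 1, `CCc1nn(CC)c(C2CCN(C(=O)CN3CN(c4ccccc4)C4(CCN(C(=O)c5ccc(C6CCCCC6)cc5)CC4)C3=O)CC2)c1C`, entry in an assay on HEK293 cells for displacement of a labelled ligand from NPC1-like intracellular cholesterol transporter 1 (Homo sapiens); a higher number here means a weaker inhibitor, a lower number a stronger inhibitor: "not determined" (no result reported)
- compound 2, `CC(C)(C)OC(=O)NCCCNC(=O)CN1CN(c2ccccc2)C2(CCN(C(=O)c3ccc(C4CCCCC4)cc3)CC2)C1=O`, gives 6000 nM in this assay
- compound 3, `CC(C)(C)OC(=O)NCCNC(=O)CN1CN(c2ccccc2)C2(CCN(C(=O)c3ccc(C4CCCCC4)cc3)CC2)C1=O`, gives 5500 nM in this assay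
- compound 4, `O=C(CN1CN(c2ccccc2)C2(CCN(C(=O)c3ccc(C4CCCCC4)cc3)CC2)C1=O)N1CCCCC1`, not yet measured

Compound 3 has the lowest of the two numbers, but the step of a 1.1-fold lower number from compound 2 to compound 3 (0.04 log units; within the scatter) lies within the scatter, so compound 2 and compound 3 are not distinguishable on these numbers. Compound 1 carries no value.

The change to compound 4 is piperidin-1-yl in place of (2-((tert-butoxycarbonyl)amino)ethyl)amino on a carbonyl carbon. Both hydrogen-bond donors and both acceptors of the leaving group go, and a ring enters in their place. Among the measured compounds shown here, the only measured step, from compound 2 to compound 3, shortened the chain inside the carbamate-bearing group while keeping the carbamate, and it moved nothing beyond the scatter; it does not test removal of the carbamate itself. For the measured compounds named here, no measured step therefore bears directly on this change, and no direction can be argued from the data. The estimate for compound 4 in this assay is 5500 nM, with a range from 1500 nM to 20000 nM. This estimate means an expected step of no change at the digits printed from compound 3 to compound 4 (within the scatter), with a wide range to reflect the missing precedent.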

Compound 4, half-maximal inhibitory concentration: 1100 nM
For compound 4 the middle estimate is 5.0-fold (0.70 log units) above the measured one; measured number below the stated range.
By their numbers in this assay, from the lowest: compound 4; then compounds 3 and 2 (each within the scatter of the next).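

In this assay, among the compounds shown here, piperidin-1-yl on the carbonyl carbon gives the first change that lies beyond the scatter, with a 5.0-fold lower number from compound 3 to compound 4 (0.70 log units; beyond the scatter) and a 5.5-fold lower number from compound 2 to compound 4 (0.74 log units; beyond the scatter) both modest. The position therefore does respond to the group it carries, which the chain shortening in a 1.1-fold lower number from compound 2 to compound 3 (0.04 log units; within the scatter) did not show, and the lower number comes with an entering group that has no hydrogen-bond donor or acceptor. Nothing measured here accounts for the step.

The change removes the carbamate and introduces the ring together, so these compounds cannot separate the two. A free primary amine on the ethyl chain, or diethylamino or morpholin-4-yl on the same carbonyl carbon, would address that, and compound 1, with its larger amide end, offers no number to read.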